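This account rests on a few compounds, and the source may have more. Where it says the series, first, only, none or still open, it means among the compounds named here.

Measured compounds in an ADME assay on Huh-5-2 cells (Homo sapiens) for cytotoxicity, read by WST assay, with a stated time of 3 days; on this read-out lower numbers stand for higher toxicity in this test and higher numbers for lower toxicity in this test:

Compound 1 `COc1ccccc1COc1cc(O)c2c(=O)c(O)c(-c3ccccc3)oc2c1` gives > 100000 nM in this assay, a limit rather than a number.
Compound 2 `N#Cc1cccc(COc2cc(O)c3c(=O)c(O)c(-c4ccccc4)oc3c2)c1` gives 72000 nM in this assay.
Compound 3 `COc1cccc(COc2cc(O)c3c(=O)c(O)c(-c4ccccc4)oc3c2)c1` gives > 100000 nM in this assay, again a limit.

Compound 3 therefore stands at the top of what this assay can report, and the limit of > 100000 nM in this assay, at which 2 of the 3 values shown sit, shows it shares that limit with compound 1. The step that the two limits leave unreadable from compound 1 to compound 3 cannot be read, while an at least 1.3-fold higher number from compound 2 to compound 3 (0.14 log units; that floor lies within the scatter) and an at least 1.3-fold lower number from compound 1 to compound 2 (0.14 log units; that floor lies within the scatter) are steps whose floors lie within the scatter.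

Compound 4 `O=c1c(O)c(-c2ccccc2)oc2cc(OCc3ccc([N+](=O)[O-])cc3)cc(O)c12` is not yet measured. It differs from compound 3 by 4-nitrophenyl in place of 3-methoxyphenyl on a saturated chain carbon bound to an oxygen on an aromatic ring. Within the data shown here, the only measured steps that concern the same place are the ones just named, and none of them reaches beyond the scatter, so the exchange of one substituted phenyl for another on this chain carbon has so far shifted the read-out little, if at all.

The expectation for compound 4 is therefore a step of a number no higher from compound 3 to compound 4 (the limit leaves the size open) in this assay, that is no change beyond the scatter. Compound 4 is estimated at 100000 nM, within 45000 nM to 220000 nM, with a real chance that this assay again reports only a limit.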

Compound 4, half-maximal cytotoxic concentration: 93000 nM
Compound 4: middle estimate off by 1.1-fold (0.03 log units), on the high side; low and high end bracket the measured number.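

In this assay, compound 4 gives a number rather than a limit, so 4-nitrophenyl on this saturated chain carbon can be compared directly with the 3-cyanophenyl of compound 2, and the result is a 1.3-fold higher number from compound 2 to compound 4 (0.11 log units; within the scatter). Against the two methoxyphenyl compounds only floors can be read, an at least 1.0-fold lower number from compound 3 to compound 4 (0.03 log units; that floor lies within the scatter) and an at least 1.0-fold lower number from compound 1 to compound 4 (0.03 log units; that floor lies within the scatter), so no readable step among these four substituted phenyl groups goes beyond the scatter, now also with a nitro group on the ring. Compound 1 and compound 3 remain limits, not numbers: the limit of > 100000 nM in this assay, at which 2 of the 4 values shown sit.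

The compounds shown leave open whether a phenyl ring carrying an amine or a carboxylic acid on this chain carbon would move the number beyond the scatter. They also leave open whether a longer chain in place of the benzyl link would do so.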